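A Methyl Gives Way to Hydrogen

This account rests on a few compounds, and the source may have more. Where it says the series, first, only, none or still open, it means among the compounds named here.

In an ADME assay on L6 cells (Rattus norvegicus) for cytotoxicity, read by resazurin assay, with a stated time of 70 h (a lower number here means a stronger inhibitor, a higher number a weaker inhibitor), compound 1 (`Cc1ccccc1C(=O)Nc1cc(Cl)ccn1`) gives 224000 nM, compound 2 (`Cc1cc(Br)ccc1C(=O)Nc1ccccn1`) gives 193000 nM and compound 3 (`Cc1ccnc(NC(=O)c2ccc(F)c(F)c2C)c1`) gives 223000 nM. Compound 3 thus stands with the other two inside the scatter, separated from neither. Compound 4 (`Cc1c(C(=O)Nc2ccccn2)ccc(F)c1F`) has hydrogen in place of methyl on an aromatic carbon, opposite the ring nitrogen: hydrogen in place of methyl on an aromatic carbon. For the measured compounds named here, no measured pair isolates this change. Compound 2, which also carries hydrogen at that place, gives 193000 nM, so no step beyond the scatter is expected in this assay. The estimated step of a 1.1-fold lower number from compound 3 to compound 4 (0.04 log units; within the scatter) is expected to stay within the scatter. For compound 4 the expected value is 205000 nM, with an estimated range of 135000 nM to 300000 nM.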

Compound 4, half-maximal inhibitory concentration: 308000 nM
Compound 4: the middle estimate sits 1.5-fold (0.18 log units) below what was measured; the whole stated range lies below it.
By their numbers in this assay, from the lowest: compounds 2, 3, 1 and 4 (each within the scatter of the next).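

In this assay, for the compounds shown here, hydrogen in place of methyl on an aromatic carbon, opposite the ring nitrogen, gives a 1.4-fold higher number from compound 3 to compound 4 (0.14 log units; within the scatter) as the first measured step that isolates this change. The methyl group at this place can therefore be lost without separating compound 4 from compound 3 beyond the scatter. No measurement shown here offers an explanation for this result. Going by these compounds, whether another group at this place, such as an amine, a carboxylic acid or a longer chain, would give a step beyond the scatter remains open.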